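Amino in place of methoxy on the benzyl naphthalene core

A few compounds are considered here, and "the series" means these few. Any claim that something is new, unique, unknown or untested is made for them only; others in the source may bear on it.

Compound 1 `Oc1c(Cc2cccc(Cl)c2)ccc2ccccc12` and compound 2 `COc1c(Cc2ccccc2)ccc2ccccc12` share the same core. In an assay on RBL-1 cells with Polyunsaturated fatty acid 5-lipoxygenase (Rattus norvegicus) as the target (a lower number here means a stronger inhibitor, a higher number a weaker inhibitor), compound 1 gives 52 nM, while in this assay compound 2 gives 55000 nM, the highest of the two numbers, with compound 1 at a far lower number, beyond the scatter. The two differ in more than one place, so only what their two values show can be said.

Compound 3 `Nc1c(Cc2ccccc2)ccc2ccccc12` makes a single change from compound 2: amino in place of methoxy on an aromatic carbon. Among the measured compounds shown here, no measured pair here gives the size of such a step. Compound 2 stands at the top of the numbers, and the amino brings back a hydrogen-bond donor, as carried by the hydroxyl of compound 1 with its 52 nM in this assay. The expected step, a 22-fold lower number from compound 2 to compound 3 (1.34 log units; beyond the scatter), is therefore downward, well beyond the scatter but short of the number of compound 1. Compound 3 is estimated at 2500 nM, within a range of 300 nM to 20000 nM.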

Compound 3, half-maximal inhibitory concentration: 9100 nM
For compound 3 the middle estimate is 3.6-fold (0.56 log units) below the measured one, within the range that was stated.
By their numbers in this assay, from the lowest: compound 1; then compound 3; then compound 2.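

In this assay, amino in place of methoxy on this aromatic carbon, ortho to a group of 7 heavy atoms, gives a 6.0-fold lower number from compound 2 to compound 3 (0.78 log units; beyond the scatter), a modest step but beyond the scatter. Among the compounds shown here, this is the first single-place step, and it shows that the number responds to the group at this position, with amino bringing a hydrogen-bond donor where methoxy has none. No measurement available here accounts for this step or its size.

For the compounds shown here, compound 1 differs from compound 3 in more than one place, so no step links them and the separate contributions of its hydroxyl and its chlorine remain unread. Going by these compounds, whether the step tracks the donor alone stays open, and a methylamino group or an acetamide on this same carbon would extend the comparison.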